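A few compounds are considered here, and "the series" means these few. Any claim that something is new, unique, unknown or untested is made for them only; others in the source may bear on it.

For the measured compounds named here, in a functional assay (Platelet, plasma) for inhibition, with Homo sapiens as the target (a higher number here means a weaker inhibitor, a lower number a stronger inhibitor), three compounds that share a core have numbers so far. Compound 1 (`N#Cc1cc2c(nc1N1CC(C(=O)NS(=O)(=O)c3ccc(Cl)s3)C1)COC2=O`) gives 193000 nM, compound 2 (`Cc1ccc(CS(=O)(=O)NC(=O)C2(F)CCN(c3nc4c(cc3C#N)C(=O)OC4)CC2)cc1`) gives 32800 nM, and compound 3 (`N#Cc1cc2c(nc1N1CCC(C(=O)NS(=O)(=O)Cc3cccc(F)c3)CC1)COC2=O`) gives 70500 nM. Compound 3 therefore stands second highest of the three. Compound 2 lies below it and compound 1 above it, and both gaps are beyond the usual scatter of repeated measurements, though neither is wide.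

The next compound, compound 4 (`N#Cc1cc2c(nc1N1CCC(C(=O)NS(=O)(=O)Cc3ccc(C(F)(F)F)cc3)CC1)COC2=O`), has yet to be measured. It has 4-(trifluoromethyl)phenyl in place of 3-fluorophenyl on a saturated chain carbon bound to a sulfonyl sulfur. Cut one bond further out, the change reads 3-fluorobenzyl to 4-(trifluoromethyl)benzyl.

Going by the values given here, no two measured compounds differ in just one place, so the data hold no direct precedent for this change. Among the compounds with values here, the only guide to size is the spread of the measured values, from compound 2 at 32800 nM to compound 1 at 193000 nM. A modest step toward a lower number is expected in this assay, though one within the scatter would be no surprise. The estimated change is a 1.6-fold lower number from compound 3 to compound 4 (0.19 log units; within the scatter). Compound 4 is estimated at 45000 nM, with an expected range of 15000 nM to 130000 nM.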

Compound 4, half-maximal inhibitory concentration: 15900 nM
The estimate for compound 4 lay 2.8-fold (0.45 log units) above the measured number; the range from low to high includes it.
By their numbers in this assay, from the lowest: compound 4; then compound 2; then compound 3; then compound 1.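

In this assay, for the compounds shown here, placing 4-(trifluoromethyl)phenyl in place of 3-fluorophenyl on a saturated chain carbon bound to a sulfonyl sulfur gives a 4.4-fold lower number from compound 3 to compound 4 (0.65 log units; beyond the scatter), the first step here that can be read between two compounds differing in one place. Unlike the earlier compounds, which differ from one another in more than one place, this pair shows that the number responds to the aryl group alone while the rest of the molecule stays the same, and that this change moves it toward a stronger inhibitor beyond the scatter. Nothing measured here accounts for the size or direction of this step.

Compound 3 and compound 4 differ both in the substituent and in where it sits on the phenyl ring, so this single step cannot show which of the two matters. Also open, from the compounds shown here alone, are how a methoxy group or an amine on that phenyl ring would read, and whether the same exchange would give a similar step with the other parts of the molecule found in compound 1 or compound 2.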